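The compounds below may be only part of what the source reports. "The series", "measured", "known", "first", "only" and "open" are said of these compounds alone.

Measured compounds:
- compound 1, `CCCC[C@H](NC(=O)[C@H](CCCCN)NC(=O)[C@H](CCCNC(=N)N)NC(=O)c1ccccc1)C(N)=O`, in an ADME assay for permeability, using PAMPA (on this read-out lower numbers stand for lower permeability and higher numbers for higher permeability), compound 1 gives "impermeable" (no number reported)
- compound 2, `CCCC[C@H](NC(=O)[C@H](CCCN)NC(=O)[C@H](CCCNC(=N)N)NC(=O)c1ccc(/C=C2\SC(=O)N(Cc3ccccc3)C2=O)cc1)C(N)=O`, in this assay compound 2 gives "impermeable" (no number reported)
- compound 3, `CCCC[C@H](NC(=O)[C@H](CCCCN)NC(=O)[C@H](CCCNC(=N)N)NC(=O)c1ccc(/C=C2\SC(=O)N(Cc3ccc(F)cc3)C2=O)cc1)C(N)=O`, in this assay compound 3 gives 0.43 10^-6 cm/s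

Compound 1 carries the shared peptide-like core with a plain benzoyl group at its end, and in this assay it yields no number at all: the read-out for compound 1 is "impermeable" (no number reported), so there is no single value to place it against compound 3. Compound 2, which also comes back as "impermeable" (no number reported), adds nothing numeric either. Only compound 3 gives a figure, 0.43 10^-6 cm/s, which is a low permeability.

Compound 4, `CCCC[C@H](NC(=O)[C@H](CCCCN)NC(=O)[C@H](CCCNC(=N)N)NC(=O)c1ccc(/C=C2\SC(=O)N(CCCC)C2=O)cc1)C(N)=O`, is reached from compound 1 by one change: a group of 12 heavy atoms (8 carbon, 1 nitrogen, 2 oxygen, 1 sulfur; one five-membered non-aromatic ring with 2 hetero atoms) in place of a hydrogen atom, on an aromatic carbon. For the measured compounds named here, no measured step covers exactly this change, so the expected size of the step in this assay must be judged from compound 3, the one related cap-bearing compound with a number. The expectation is a move from "no number" to a small but measurable permeability, not beyond a modest level.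

Compound 4 is expected to give about 0.3 10^-6 cm/s in this assay, with a likely range from 0.08 10^-6 cm/s to 1 10^-6 cm/s, and a real chance that it too is reported only as impermeable.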

Compound 4, apparent permeability: 1.18 10^-6 cm/s
Compound 4: the middle estimate sits 3.9-fold (0.59 log units) below what was measured; the whole stated range lies below it.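

In this assay, the group on the ring nitrogen proves to be a place where the read-out shifts: propyl in place of 4-fluorophenyl, on the saturated chain carbon bound to that nitrogen, gives a 2.7-fold higher number from compound 3 to compound 4 (0.44 log units; beyond the scatter). The first numbers also show that an uncapped compound and a capped one can differ sharply, as compound 1 gives "impermeable" (no number reported), while compound 4, with the five-membered ring group on its aromatic carbon, gives 1.18 10^-6 cm/s. Nothing available here explains either difference.

For the compounds shown here, only two groups with a number have been seen at this position, so it remains open whether a longer chain or a chain ending in an amine would raise or lower the read-out. The step also replaces the whole 4-fluorophenyl at once, leaving the part played by the fluorine unresolved.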